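From methoxy to methyl: compound 2 to compound 3

This account rests on a few compounds, and the source may have more. Where it says the series, first, only, none or still open, it means among the compounds named here.

Compound 1 `Cc1ccc(Sc2cccc(N)c2C#N)cc1`: > 200000 nM
Compound 2 `COc1ccc([S+]([O-])c2cccc(N)c2C#N)cc1`: > 200000 nM

Both results come from a functional assay on MT4 cells (Homo sapiens) for cytotoxicity; on this read-out higher numbers stand for weaker inhibition and lower numbers for stronger inhibition. Compound 2 gives > 200000 nM, which is a limit of the assay and not a number. Compound 1 also stands at a limit, > 200000 nM. The whole picture so far is the limit of > 200000 nM in this assay, at which 2 of the 2 values shown sit.

Compound 3 `Cc1ccc([S+]([O-])c2cccc(N)c2C#N)cc1` keeps the rest of compound 2 but has methyl in place of methoxy on an aromatic carbon, para to a large group (methyl in place of methoxy on an aromatic carbon). For the measured compounds named here, no measured step shows what such a change does. The expectation rests on compound 1, which also carries methyl and stands at the limit of > 200000 nM. In this assay, no change beyond the usual scatter is expected, so the estimated step is a number no higher from compound 2 to compound 3 (the limit leaves the size open). For compound 3, the estimated value is 200000 nM, with an expected range from 100000 nM to 300000 nM.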

Compound 3, half-maximal inhibitory concentration: > 200000 nM
Compound 3: a limit, no number (the forecaster's own chance of this, stated with the estimate: 85%); the middle value lies on the limit itself.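

Compound 2 and compound 3 both stand at a limit and not at a number, so no step can be read between them: the limit of > 200000 nM in this assay, at which 3 of the 3 values shown sit.

The compounds shown leave open whether methyl in place of methoxy on an aromatic carbon changes the read-out at all.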